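The source may hold more compounds than are shown below. What is called first, only, known or untested is meant among the compounds shown, and "the series" means these compounds.

Measured in a functional assay on A-431 cells (Homo sapiens) for antiproliferative activity, read by MTT assay, with a stated time of 72 h; on this read-out higher numbers stand for weaker inhibition and lower numbers for stronger inhibition:
compound 1 `CN1CCN(Cc2ccc(NC(=O)Nc3ccc4ncnc(Nc5ccc(F)c(Cl)c5)c4c3)cc2)CC1`, 4000 nM
compound 2 `C#Cc1cccc(Nc2ncnc3ccc(NC(=O)Nc4ccc(CN5CCN(C)CC5)cc4)cc23)c1`, 2810 nM
compound 3 `COc1ccc(Nc2ncnc3ccc(NC(=O)Nc4ccc(CN5CCN(C)CC5)cc4)cc23)cc1Cl`, 2010 nM

Compound 3 sits at the low end of these three numbers, but only nominally: a 2.0-fold lower number from compound 1 to compound 3 (0.30 log units; within the scatter); a 1.4-fold lower number from compound 2 to compound 3 (0.15 log units; within the scatter). Compound 4 `CN1CCN(Cc2ccc(NC(=O)Nc3ccc4ncnc(Nc5cccc(C(F)(F)F)c5)c4c3)cc2)CC1` has not yet been measured. Its change from compound 3 is 3-(trifluoromethyl)phenyl in place of 3-chloro-4-methoxyphenyl on a nitrogen on an aromatic ring. Two measured steps exchange the aryl group on that same nitrogen, and both stay inside the scatter: a 1.4-fold lower number from compound 1 to compound 2 (0.15 log units; within the scatter) and a 1.4-fold lower number from compound 2 to compound 3 (0.15 log units; within the scatter). The third aryl exchange, from compound 1 to compound 3, also stays inside the scatter. On this basis no step beyond the scatter is expected in this assay in either direction, which as an estimate means a 1.2-fold higher number from compound 3 to compound 4 (0.09 log units; within the scatter). Compound 4 is therefore estimated at 2500 nM, range 1000 nM to 6500 nM.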

Compound 4, half-maximal inhibitory concentration: 2410 nM
For compound 4 the middle estimate is 1.0-fold (0.02 log units) above the measured one; the measured number falls inside the stated range.
By their numbers in this assay, from the lowest: compounds 3, 4, 2 and 1 (each within the scatter of the next).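

In this assay, a aryl exchange that removes the only hydrogen-bond acceptor of the group on this nitrogen, the methoxy oxygen, gives a 1.2-fold higher number from compound 3 to compound 4 (0.08 log units; within the scatter) and so does not separate the two compounds. Trifluoromethyl in place of ethynyl gives a 1.2-fold lower number from compound 2 to compound 4 (0.07 log units; within the scatter), and 3-(trifluoromethyl)phenyl in place of 3-chloro-4-fluorophenyl gives a 1.7-fold lower number from compound 1 to compound 4 (0.22 log units; within the scatter), so all four aryl groups remain within the scatter of one another. No measurement at hand explains this flat response.

From the compounds shown here alone, whether an amine or a carboxylic acid on this aryl ring would produce a step beyond the scatter remains open. Also open, going by these compounds, is whether any change away from this nitrogen, such as replacing the methylpiperazine with a morpholine, would do so.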